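Methoxy for trifluoromethyl: a repeated swap in two cores

The source may report more compounds than this note shows. Statements on the series, on what has been measured and on what is new or still open speak of the compounds shown alone.

Compound 1 `NC(=O)c1c(NC(=O)c2ccccc2C(F)(F)F)sc2c1CCN(C(=S)Nc1ccccc1Cl)C2` and compound 2 `COc1ccccc1C(=O)Nc1sc2c(c1C(N)=O)CCN(C(=S)Nc1ccccc1Cl)C2` share one core; compound 3 `NC(=O)c1c(NC(=O)c2ccccc2I)sc2c1CCN(C(=S)Nc1ccccc1C(F)(F)F)C2` and compound 4 `COc1ccccc1NC(=S)N1CCc2c(sc(NC(=O)c3ccccc3I)c2C(N)=O)C1` share another. The difference between the two cores is not broken down here. In a functional assay on MKN-74 cells (Homo sapiens) for antiproliferative activity, with a stated time of 24 h (on this read-out higher numbers stand for weaker inhibition and lower numbers for stronger inhibition), compound 1 gives 21900 nM, and compound 2 gives 20500 nM. Compound 3 gives 14200 nM in this assay, and the gaps from compound 3 to compound 2 and to compound 1 both lie within the scatter, so no order among the three is claimed.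

The change from compound 1 to compound 2 is methoxy in place of trifluoromethyl on an aromatic carbon. It made a 1.1-fold lower number from compound 1 to compound 2 (0.03 log units; within the scatter). The change from compound 3 to compound 4 is methoxy in place of trifluoromethyl on an aromatic carbon. The two place lines read the same, but the wider reading differs: for compound 3 to compound 4 it also reads (2-(trifluoromethyl)phenyl)amino to (2-methoxyphenyl)amino, which is absent for compound 1 to compound 2. It is therefore taken as the same kind of change, sitting in a different part of the molecule. It occurs twice among these compounds, and the single measured instance is a guide of limited weight.

For compound 4 the expected step is a 1.1-fold lower number from compound 3 to compound 4 (0.02 log units; within the scatter), beside the earlier one, because the measured step of a 1.1-fold lower number from compound 1 to compound 2 (0.03 log units; within the scatter) was within the scatter. Compound 4 is estimated at 13500 nM in this assay, expected to fall between 6000 nM and 30000 nM.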

Compound 4, half-maximal inhibitory concentration: 41800 nM
Estimate against measurement, compound 4: 3.1-fold (0.49 log units) below, and the stated range ends below it.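

In this assay, methoxy in place of trifluoromethyl on an aromatic carbon gave a 2.9-fold higher number from compound 3 to compound 4 (0.47 log units; beyond the scatter), so compound 4 does not repeat the flat result of the first pair, and the step size did not carry from one core to the other: the same change on two cores in this assay, a 1.1-fold lower number (0.03 log units; within the scatter) from compound 1 to compound 2 and a 2.9-fold higher number (0.47 log units; beyond the scatter) from compound 3 to compound 4, 3.1-fold (0.50 log units) apart, beyond the scatter of two such steps The change is therefore not interchangeable across these two cores, and a step measured on one of them is a poor guide to the other in this series. Going by these compounds alone, what this does not show is why the two steps part: there are only two pairs, they differ in core, and the swap sits in a different part of the molecule in each, on the (2-(trifluoromethyl)phenyl)amino end only in the pair of compound 3 and compound 4, so core and site cannot be separated, and the step itself is modest.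

Open, on these data alone, is whether the higher number of compound 4 belongs to methoxy as such or to losing trifluoromethyl at this place, a question that an ethoxy chain or a primary amine on the same aromatic carbon would address. Also open, as far as these compounds go, is whether the same swap on the (2-(trifluoromethyl)phenyl)amino end behaves alike when the rest of the molecule is that of compound 1.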